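A few compounds are considered here, and "the series" means these few. Any claim that something is new, unique, unknown or untested is made for them only; others in the source may bear on it.

Compound 1 `CCC[C@@H](OC(C)=O)C1=C(Br)C(=C(Br)Br)OC1=O` gives 0.3 ug/mL in a functional assay on KB cells (Homo sapiens) for cytotoxicity; on this read-out higher numbers stand for an effect only at larger amounts of compound and lower numbers for an effect already at smaller amounts. Compound 3 `CCCCC1=C(Br)C(OC)(C(Br)Br)OC1=O` gives 7.6 ug/mL in this assay. Compound 2 `CCCCCCC(=O)C(Br)=C(Br)Br` returns only a limit in this assay, > 20 ug/mL, not a number.

Among the two numbers known, compound 1 stands lowest; compound 3 sits well beyond the usual scatter from it. Compound 2 reaches (the limit of > 20 ug/mL in this assay, at which 1 of the 3 values shown sits). Compound 4 `CCC[C@@H](O)C1=C(Br)C(=C(Br)Br)OC1=O`, not yet measured, differs from compound 1 by hydrogen in place of acetyl on an oxygen on a saturated carbon. Among the compounds with values here, no measured pair shows this same change, so the step from compound 1 to compound 4 is expected to be modest, toward a higher number in this assay, and possibly within the scatter. Compound 4 is therefore estimated at 1 ug/mL, with a range from 0.2 ug/mL to 5 ug/mL. The expected step is a 3.3-fold higher number from compound 1 to compound 4 (0.52 log units; beyond the scatter).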

Compound 4, concentration for half-maximal effect: 0.5 ug/mL
Beside the measured number, compound 4's estimate is 2.0-fold (0.30 log units) above it; the measured number falls inside the stated range.
By their numbers in this assay, from the lowest: compounds 1 and 4 (each within the scatter of the next); then compound 3. At a limit, above all of these: compound 2.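

In this assay, within the data shown here, the change from acetoxy to hydroxy gives a 1.7-fold higher number from compound 1 to compound 4 (0.22 log units; within the scatter) and is the first single change that can be read. At this oxygen on a saturated carbon, the acetyl can therefore be removed without a change that stands clear of the scatter, so the free hydroxy serves as well as the ester here. Nothing shown gives a reason for this result.

Still open, from the compounds shown here alone, is whether a methyl ether or a longer ester on this oxygen would behave the same way. An amine in place of the hydroxy is also untested here.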